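Indole nitrogen substituent series: estimate for compound 4

This account rests on a few compounds, and the source may have more. Where it says the series, first, only, none or still open, it means among the compounds named here.

Measured compounds:
compound 1 `C/C(=C\C(=O)Nc1ccccc1OCCCC(=O)O)c1ccc2c(ccn2CC(C)C)c1` — 160 nM
compound 2 `CCCC(C(C)C)n1ccc2cc(/C(C)=C/C(=O)Nc3ccccc3OCCCC(=O)O)ccc21` — 7.2 nM
compound 3 `C/C(=C\C(=O)Nc1ccccc1OCCCC(=O)O)c1ccc2c(ccn2C(C(C)C)C(C)C)c1` — 14 nM

All three share one core and differ only in the group on the aromatic nitrogen. In an assay on Prostate gland for inhibition of steroid 5-alpha-reductase (Rattus norvegicus) (on this read-out higher numbers stand for weaker inhibition and lower numbers for stronger inhibition), compound 3 stands second highest of the three numbers; its nearest neighbour is compound 2 (a 1.9-fold higher number from compound 2 to compound 3 (0.29 log units; within the scatter)), and its furthest is compound 1 (an 11-fold lower number from compound 1 to compound 3 (1.06 log units; beyond the scatter)). Compound 4 `COc1ccc(Cn2ccc3cc(/C(C)=C/C(=O)Nc4ccccc4OCCCC(=O)O)ccc32)cc1` is not yet measured. The change from compound 3 is 4-methoxybenzyl in place of 1-isopropyl-2-methylpropyl on an aromatic nitrogen.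

The measured steps that bear on this place are a 22-fold lower number from compound 1 to compound 2 (1.35 log units; beyond the scatter) and an 11-fold lower number from compound 1 to compound 3 (1.06 log units; beyond the scatter), both large, and a 1.9-fold higher number from compound 2 to compound 3 (0.29 log units; within the scatter), which is within the scatter. They show that the number responds strongly to what sits on the aromatic nitrogen, but none of them involves an aromatic ring at that place, so the direction for a 4-methoxybenzyl group is not covered by the data. Compound 4 is therefore expected to land within the span set by compound 1 and compound 2, with a step of a 2.5-fold higher number from compound 3 to compound 4 (0.40 log units; beyond the scatter) as the working estimate. Compound 4 is estimated at 35 nM in this assay, in the range 7 nM to 180 nM.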

Compound 4, half-maximal inhibitory concentration: 480 nM
For compound 4 the middle estimate is 14-fold (1.14 log units) below the measured one; the measured number lies above the stated range.
By their numbers in this assay, from the lowest: compounds 2 and 3 (each within the scatter of the next); then compound 1; then compound 4.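

In this assay, 4-methoxybenzyl on the aromatic nitrogen gives a 34-fold higher number from compound 3 to compound 4 (1.54 log units; beyond the scatter) and a 67-fold higher number from compound 2 to compound 4 (1.82 log units; beyond the scatter), so the first group shown here with a six-membered aromatic ring of carbon only leaves compound 4 the weakest inhibitor of the four. The comparison with the unbranched alkyl group is much smaller, at a 3.0-fold higher number from compound 1 to compound 4 (0.48 log units; beyond the scatter), and among these four compounds the two with no branch on the saturated chain carbon bound to the aromatic nitrogen, compound 1 and compound 4, both give higher numbers than the two branched ones, compound 2 and compound 3, with no compound against this pattern. Nothing measured here gives a reason for these steps.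

The compounds shown cannot separate the contribution of the ring from that of its methoxy group, a question that a plain benzyl or a cyclohexylmethyl group on the aromatic nitrogen would address. Also open, as far as these compounds go, is whether an aromatic ring on a branched carbon, as in a 1-phenylbutyl group, would keep the low numbers of compound 2 and compound 3.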